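The source may hold more compounds than are shown below. What is called first, only, known or untested is meant among the compounds shown, and "the series" means these compounds.

Compound 1 `CC(=O)c1ccc(-c2ccc3c(C(=O)Nc4cccc(F)c4)cc(=O)[nH]c3c2)cc1`: > 20000 nM
Compound 2 `O=C(Nc1cccc(F)c1)c1cc(=O)[nH]c2cc(-c3ccc(F)nc3)ccc12`: > 20000 nM

Both values come from a functional assay on KYSE-70 cells for antiproliferative activity against KYSE-70 cell line (Homo sapiens), read by MTT assay, with a stated time of 72 h; a lower number here means a stronger inhibitor, a higher number a weaker inhibitor. In this assay, compound 2 gives > 20000 nM, which is a limit and not a number. The same limit holds for compound 1, so the two compounds give no ranking: the limit of > 20000 nM in this assay, at which 2 of the 2 values shown sit.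

Compound 3 `C#Cc1ccc2c(C(=O)Nc3cccc(F)c3)cc(=O)[nH]c2c1` keeps the shared core and the amide side of compound 2, and the change lies in one group: ethynyl in place of 6-fluoropyridin-3-yl on an aromatic carbon. In words, ethynyl takes the place of 6-fluoropyridin-3-yl on an aromatic carbon.

Among the measured compounds shown here, the only measured step bearing on this is a step that the two limits leave unreadable from compound 1 to compound 2, so there is no size to carry over. For the measured compounds named here, with no measured step to argue from, no change beyond the scatter is expected, and no direction can be given. The estimated change is a step that the limit leaves unreadable from compound 2 to compound 3.

For compound 3, the expected value is 25000 nM, with an estimated range from 8000 nM to 60000 nM.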

Compound 3, half-maximal inhibitory concentration: 9500 nM
Compound 3: the middle estimate sits 2.6-fold (0.42 log units) above what was measured; measured number inside the range.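

In this assay, this position on the shared core now gives its first readable change: ethynyl in place of 6-fluoropyridin-3-yl gives an at least 2.1-fold lower number from compound 2 to compound 3 (0.32 log units; beyond the scatter), and ethynyl in place of 4-acetylphenyl gives an at least 2.1-fold lower number from compound 1 to compound 3 (0.32 log units; beyond the scatter). The activity of these compounds therefore does depend on the group at this aromatic carbon, and here a group with no ring does better than the two groups that carry a six-membered aromatic ring. The true size of both steps stays unknown, because the starting values are limits and not numbers: the limit of > 20000 nM in this assay, at which 2 of the 3 values shown sit.

As far as these compounds go, it remains open whether the gain comes from losing the ring or from the triple bond itself. A nitrile, an amine or a short alkyl chain at this position could help separate the two.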